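A tert-butyl group on compound 1

The source may hold more compounds than are shown below. What is called first, only, known or untested is meant among the compounds shown, and "the series" means these compounds.

compound 1 `NC1=NC2(CCOCC2)N(OCCCOc2ccccc2)C(N)=N1`: 1080 nM
compound 2 `NC1=NC2(CCOCC2)N(OCCCOc2cccc(Cl)c2Cl)C(N)=N1`: 100 nM
compound 3 `NC1=NC2(CCOCC2)N(OCCCOc2cccc(Cl)c2)C(N)=N1`: 150 nM

In a functional assay on A549 cells (Homo sapiens) for antiproliferative activity, read by MTT assay, with a stated time of 72 h (on this read-out higher numbers stand for weaker inhibition and lower numbers for stronger inhibition), compound 1 gives 1080 nM, the highest of the three numbers, and so it is the weakest inhibitor of the set. Two measured steps start from it, and both lie beyond the scatter: a 7.2-fold lower number from compound 1 to compound 3 (0.86 log units; beyond the scatter) and an 11-fold lower number from compound 1 to compound 2 (1.03 log units; beyond the scatter). The remaining step, a 1.5-fold higher number from compound 2 to compound 3 (0.18 log units; within the scatter), stays within the scatter.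

Compound 4 `CC(C)(C)c1ccc(OCCCON2C(N)=NC(N)=NC23CCOCC3)cc1` is still unmeasured. It differs from compound 1 by one change: tert-butyl in place of hydrogen on an aromatic carbon, para to a large group. The closest evidence is the pair of chloro steps, a 7.2-fold lower number from compound 1 to compound 3 (0.86 log units; beyond the scatter) and an 11-fold lower number from compound 1 to compound 2 (1.03 log units; beyond the scatter), which both lowered the number. Going by the values given here, neither adds a tert-butyl, and no measured compound carries a group at this place, so the comparison is loose. A lower number is expected in this assay, though with less confidence than those steps might suggest. The expected step is a 4.3-fold lower number from compound 1 to compound 4 (0.64 log units; beyond the scatter). Compound 4 is estimated at 250 nM, with an expected range of 70 nM to 900 nM.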

Compound 4, half-maximal inhibitory concentration: 500 nM
The estimate for compound 4 lay 2.0-fold (0.30 log units) below the measured number; low and high end bracket the measured number.
By their numbers in this assay, from the lowest: compounds 2 and 3 (each within the scatter of the next); then compound 4; then compound 1.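

In this assay, the first group placed on an aromatic carbon para to a large group still lowers the number, with a 2.2-fold lower number from compound 1 to compound 4 (0.33 log units; beyond the scatter), so this place accepts a tert-butyl, with its 4 heavy atoms and no ring, without a loss against the unsubstituted phenyl. The lowering seen with chloro is therefore not the only case: compounds 2, 3 and 4 all stand lower than compound 1 in this set, and none goes against that. No measurement shown here accounts for the step.

As far as these compounds go, whether a chloro or a methoxy group at this same place would lower the number further remains open. So does whether an amine or a carboxylic acid would be accepted there, or whether tert-butyl would add to the effect of chloro on the same ring.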